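Compound 3 to Compound 4: A Difluorophenyl Swap

The source may report more compounds than this note shows. Statements on the series, on what has been measured and on what is new or still open speak of the compounds shown alone.

Of the compounds shown here, three sharing one core have been tested in a functional assay on NALM-6 cells (Homo sapiens) for cytotoxicity, with a stated time of 72 h; on this read-out lower numbers stand for an effect already at smaller amounts and higher numbers for an effect only at larger amounts of compound. Compound 1 (`C=C[C@@](C)(/C=C/c1ccc(OCc2ccccc2)cc1)CCC=C(C)C`) gives > 43400 nM, which is a limit and not a number. Compound 2 (`C=C[C@@](C)(/C=C/c1ccc(Nc2ccc(F)cc2)cc1)CCC=C(C)C`) gives > 43400 nM, again a limit. Compound 3 (`C=C[C@@](C)(/C=C/c1ccc(Nc2ccc(F)c(F)c2)cc1)CCC=C(C)C`) gives > 43400 nM, also a limit, so its place on the scale is not known as a number. All three share (the limit of > 43400 nM in this assay, at which 3 of the 3 values shown sit).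

Compound 4 (`C=C[C@@](C)(/C=C/c1ccc(Nc2cc(F)cc(F)c2)cc1)CCC=C(C)C`) has the same atoms as compound 3, joined differently, with 3,5-difluorophenyl in place of 3,4-difluorophenyl on a nitrogen on an aromatic ring.

The nearest guide is a step that the two limits leave unreadable from compound 2 to compound 3. A second guide is a step that the two limits leave unreadable from compound 1 to compound 3, and a third is a step that the two limits leave unreadable from compound 1 to compound 2. None of these gives a size or a direction, so no shift beyond the usual scatter is expected. The expected outcome is a step that the limit leaves unreadable from compound 3 to compound 4. Another limit is the most likely report. For compound 4 the estimated value is 45000 nM, with an expected range from 15000 nM to 90000 nM.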

Compound 4, half-maximal effective concentration: > 43400 nM
Compound 4 ended at the assay's limit (the forecaster's own chance of this, stated with the estimate: 85%); the middle value does not contradict the limit.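

The steps linking compound 4 to compound 1, compound 2 and compound 3 cannot be read in this assay, because each rests on limits and not on numbers: the limit of > 43400 nM in this assay, at which 4 of the 4 values shown sit. The compounds shown leave open where any of them would stand as a number, and whether 3,5-difluorophenyl and 3,4-difluorophenyl differ at all.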